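Oxadiazole in place of thiophene on the shared core

This account rests on a few compounds, and the source may have more. Where it says the series, first, only, none or still open, it means among the compounds named here.

The series rests on a shared core carrying a five-membered ring on an aromatic carbon. Compound 1 `Cc1nc(-c2ccccc2NCC2=NCCN2)cs1` gives in a functional assay for activation of Alpha-1D adrenergic receptor (Homo sapiens) (a higher number here means that more compound is needed for the effect, a lower number that less compound is needed), a value that is a limit of the assay, < 5020 nM. Compound 3 `Cc1noc(-c2ccccc2NCC2=NCCN2)n1` likewise gives only a limit in this assay, < 5020 nM. Compound 2 `c1csc(-c2ccccc2NCC2=NCCN2)c1` gives in this assay 18.2 nM, the only number shown among the three, so nothing places it above or below its neighbours. The steps a step that the limit leaves unreadable from compound 1 to compound 2, a step that the two limits leave unreadable from compound 1 to compound 3 and a step that the limit leaves unreadable from compound 2 to compound 3 are all unreadable because of the limit of < 5020 nM in this assay, at which 2 of the 3 values shown sit.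

Compound 4 `Cc1nc(-c2ccccc2NCC2=NCCN2)no1` differs from compound 2 as 5-methyl-1,2,4-oxadiazol-3-yl in place of thiophen-2-yl on an aromatic carbon. No measured step can be read for a ring change of this kind, and the isomeric ring of compound 3 gives only a limit. He therefore expects a sizeable step of uncertain direction, estimated as a 55-fold higher number from compound 2 to compound 4 (1.74 log units; beyond the scatter), with a real chance that only a limit is reported. His estimate for compound 4 in this assay is 1000 nM, within 100 nM to 5020 nM.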

Compound 4, half-maximal effective concentration: < 5020 nM
Compound 4: a limit, no number; the forecaster's own chance of this, stated with the estimate: 50%; the middle value does not contradict the limit.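

Among the compounds shown here, no step from compound 4 to compound 1, compound 2 or compound 3 can be read, because the result for compound 4 is only a limit: the limit of < 5020 nM in this assay, at which 3 of the 4 values shown sit.

The compounds shown leave open how far compound 4 actually lies from compound 2 in this assay, and whether compound 3 and compound 4 differ at all.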